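Quinoline styryl series: removing the butylsulfanyl side chain

The source may hold more compounds than are shown below. What is called first, only, known or untested is meant among the compounds shown, and "the series" means these compounds.

Working notes on the series. In a functional assay on lung (Cavia porcellus) for binding affinity to cysteinyl leukotriene receptor (Homo sapiens) (a lower number here means a stronger inhibitor, a higher number a weaker inhibitor), compound 1 `CCCCSc1ccc2ccc(/C=C/c3cccc(OCC(=O)OC)c3)nc2c1` gives 1500 nM, the highest of the three numbers recorded so far. Compound 2 `CC(Oc1cccc(C#Cc2ccc3ccc(Br)cc3n2)c1)C(=O)O` gives 97 nM in this assay, and compound 3 `O=C(O)CCCOc1cccc(/C=C/c2ccc3cc(Cl)ccc3n2)c1` gives 270 nM. Of the three, compound 3 lies nearest to compound 1, with a gap beyond the scatter, and compound 2 lies furthest, also beyond the scatter. Among the compounds with values here, compound 1 is the only methyl ester among the three; compound 2 and compound 3 carry a free acid, and both return lower numbers, though no single-change step links them to compound 1.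

Compound 4 `COC(=O)COc1cccc(/C=C/c2ccc3ccccc3n2)c1` is not yet measured. It differs from compound 1 in one place: hydrogen in place of butylsulfanyl on an aromatic carbon. Within the data shown here, since no measured pair in this set isolates that change, the direction rests on judgement alone. The expectation is that the step of a 2.0-fold higher number from compound 1 to compound 4 (0.30 log units; within the scatter) goes toward a weaker inhibitor by a modest margin, possibly within the scatter. For compound 4 the estimated value in this assay is 3000 nM, within a range of 800 nM to 12000 nM.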

Compound 4, half-maximal inhibitory concentration: 1000 nM
Compound 4: the middle estimate sits 3.0-fold (0.48 log units) above what was measured, within the range that was stated.
By their numbers in this assay, from the lowest: compound 2; then compound 3; then compounds 4 and 1 (each within the scatter of the next).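

In this assay, within the data shown here, the first single-change step, a 1.5-fold lower number from compound 1 to compound 4 (0.18 log units; within the scatter), shows that hydrogen can replace butylsulfanyl on this aromatic carbon without a difference beyond the scatter. Removing all 5 heavy atoms of the side chain leaves compound 1 and compound 4 indistinguishable here, so this change does not account for the gaps that separate them from compound 2 and compound 3. Nothing at hand bears on the reason for this result.

From the compounds shown here alone, whether an amine or a butoxy chain on the same aromatic carbon would give a number outside the scatter remains open. Also open, going by these compounds, is whether the same step would read alike on a core carrying a carboxylic acid instead of the methyl ester.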